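This account rests on a few compounds, and the source may have more. Where it says the series, first, only, none or still open, it means among the compounds named here.

Among the measured compounds shown here, compound 1 `COc1ccccc1Oc1cncc(C2=CC3CNCC(C2)C3)c1` is one of two compounds measured in an in vitro assay on SH-EP1 cells for displacement of a labelled ligand from Neuronal acetylcholine receptor; alpha4/beta2 (Homo sapiens); on this read-out lower numbers stand for stronger inhibition and higher numbers for weaker inhibition. In this assay compound 1 gives 1 nM, and compound 2 `Clc1ccc(C2=CC3CNCC(C2)C3)nn1` gives 0.4 nM. Of these two numbers, compound 1 stands on the higher one, and the gap to compound 2 lies beyond the usual scatter of such measurements. Compound 2 is built differently and shares only the core with compound 1, so its value says nothing direct about a small change on the outer ring of compound 1.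

Compound 3 `Clc1ccccc1Oc1cncc(C2=CC3CNCC(C2)C3)c1` has not yet been measured. Compared with compound 1, the change is chloro in place of methoxy on an aromatic carbon. For the measured compounds named here, no measured pair shows the effect of this change. The step from compound 1 to compound 3 in this assay is expected to be no change at the digits printed from compound 1 to compound 3 (within the scatter), that is, none beyond the scatter. Compound 3 is therefore estimated at 1 nM, with a likely range from 0.3 nM to 4 nM.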

Compound 3, inhibition constant: 0.9 nM
The estimate for compound 3 lay 1.1-fold (0.05 log units) above the measured number, and the stated range covers the measured number.
By their numbers in this assay, from the lowest: compound 2; then compounds 3 and 1 (each within the scatter of the next).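

In this assay, chloro in place of methoxy on an aromatic carbon, ortho to a large group, gives a 1.1-fold lower number from compound 1 to compound 3 (0.05 log units; within the scatter). This first pair that differs in one place shows that 2-methoxyphenyl can give way to 2-chlorophenyl with no readable change in the number, even though a group with two heavy atoms and one hydrogen-bond acceptor leaves and a single heavy atom with no hydrogen-bond acceptor enters. Nothing available here explains why the two groups read alike.

The compounds shown leave open whether this place accepts groups of a very different kind, such as an amine, a carboxylic acid or a longer chain like butoxy. They also leave open how the number would read with only hydrogen at this place.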